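The source may report more compounds than this note shows. Statements on the series, on what has been measured and on what is new or still open speak of the compounds shown alone.

The study opens with compound 1 `Cc1[nH]nc(N)c1-c1ccc(Cl)c(Cl)c1`. In an assay on Sf9 cells for inhibition of inhibitor of nuclear factor kappa-B kinase subunit epsilon (Homo sapiens), read by ADP-Glo, with a stated time of 60 min (on this read-out higher numbers stand for weaker inhibition and lower numbers for stronger inhibition), compound 1 gives only a limit of the assay, > 100000 nM. Compound 2 `Cc1[nH]nc(N)c1-c1cccc(Cl)c1` differs from it by hydrogen in place of chloro on an aromatic carbon. In this assay compound 2 gives 93400 nM. The step is an at least 1.0-fold lower number from compound 1 to compound 2 (0.02 log units; that floor lies within the scatter); that step carries a floor rather than a number because of the limit of > 100000 nM in this assay, at which 2 of the 3 values shown sit.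

Compound 3 `CC(=O)n1nc(C)c(-c2ccc(Cl)c(Cl)c2)c1N` rests on another core; the difference between the two cores is not broken down here. In this assay compound 3 gives only a limit of the assay, > 100000 nM.

Compound 4 `CC(=O)n1nc(C)c(-c2cccc(Cl)c2)c1N` awaits measurement and differs from compound 3 by hydrogen in place of chloro on an aromatic carbon. This is the same kind of change as that made from compound 1 to compound 2, although the place is here para to a large group where before it was para to a group of 7 heavy atoms. The expected step for compound 4 is a step that the limit leaves unreadable from compound 3 to compound 4, which rests on the earlier step being an at least 1.0-fold lower number from compound 1 to compound 2 (0.02 log units; that floor lies within the scatter) and on compound 3 standing at a limit. Compound 4 is therefore estimated at 150000 nM, most likely reported again as a limit.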

Compound 4, half-maximal inhibitory concentration: > 100000 nM
Compound 4 was reported as a limit; the forecaster's own chance of this, stated with the estimate: 70%; the middle value lies beyond the limit too.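

In this assay compound 4 gives only a limit of the assay, > 100000 nM. Compound 3 likewise gives only a limit, > 100000 nM. No step can be read from compound 3 and compound 4 because both values are limits: the limit of > 100000 nM in this assay, at which 3 of the 4 values shown sit. The compounds shown leave open whether hydrogen in place of chloro acts alike on the core of compound 1 and the core of compound 3.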